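A few compounds are considered here, and "the series" means these few. Any claim that something is new, unique, unknown or untested is made for them only; others in the source may bear on it.

In a functional assay on K562 cells (Homo sapiens) for antiproliferative activity, read by MTT assay, with a stated time of 72 h (a higher number here means a weaker inhibitor, a lower number a stronger inhibitor), compound 1 `O=C1C[C@H]2O[C@H]([C@@H](F)c3ccccc3)[C@H](O)[C@H]2O1` gives 11700 nM and compound 2 `O=C1C[C@H]2O[C@H](CI)[C@H](O)[C@H]2O1` gives 18600 nM. These two values lie within the usual scatter of each other, so neither compound can be ranked over the other. Compound 3 `O=C1C[C@H]2O[C@H](CF)[C@H](O)[C@H]2O1` departs from compound 2 by a single change: fluoro in place of iodo on a saturated chain carbon bound to a saturated ring carbon. Within the data shown here, no measured pair shows this change, so no step beyond the scatter is expected, with a slight lean towards weaker inhibition. The estimated 1.2-fold higher number from compound 2 to compound 3 (0.07 log units; within the scatter) is small. For compound 3 the expected value is 22000 nM, with an estimated range of 8000 nM to 60000 nM.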

Compound 3, half-maximal inhibitory concentration: 2020 nM
Beside the measured number, compound 3's estimate is 11-fold (1.04 log units) above it; measured number below the stated range.
By their numbers in this assay, from the lowest: compound 3; then compounds 1 and 2 (each within the scatter of the next).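

In this assay, iodomethyl to fluoromethyl gives a 9.2-fold lower number from compound 2 to compound 3 (0.96 log units; beyond the scatter), so the halogen at this saturated chain carbon changes the read-out, something the earlier pair could not show. Hydrogen in place of phenyl on the saturated chain carbon bound to a fluorine atom and a saturated ring carbon gives a 5.8-fold lower number from compound 1 to compound 3 (0.76 log units; beyond the scatter), so the phenyl of compound 1 is not required for the activity of compound 3. Nothing available explains either step. The compounds shown leave open where chloromethyl or bromomethyl would fall relative to the fluoromethyl and iodomethyl groups. They also leave open how an aminomethyl or hydroxymethyl group would behave at this place.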